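A Third Methoxy Group on a Vinyl Sulfone Scaffold

The compounds below may be only part of what the source reports. "The series", "measured", "known", "first", "only" and "open" are said of these compounds alone.

Compound 1, with the structure `COc1ccc(CS(=O)(=O)/C=C/c2ccc(OC)c(OC)c2)cc1`, and compound 2, with the structure `COc1ccc(CS(=O)(=O)/C=C/c2cc(OC)cc(OC)c2)cc1`, share one core and differ only in where two methoxy groups sit on one of their rings. Both were tested in a functional assay on H157 cells (Homo sapiens) for antiproliferative activity, read by trypan blue exclusion; a higher number here means a weaker inhibitor, a lower number a stronger inhibitor. In this assay compound 1 reaches only the limit > 20000 nM, a boundary of the measurement rather than a number. In this assay compound 2 likewise stops at the limit > 20000 nM, again a boundary and not a number. Where compound 2 stands is therefore known only as the limit of > 20000 nM in this assay, at which 2 of the 2 values shown sit, and no step between measured compounds can be drawn from these two values.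

Compound 3, with the structure `COc1ccc(CS(=O)(=O)/C=C/c2cc(OC)c(OC)c(OC)c2)cc1`, differs from compound 2 by methoxy in place of hydrogen on an aromatic carbon, on an aromatic carbon ortho to two methoxy groups and para to a large group. For the measured compounds named here, because both measured values are limits, no measured step points in either direction. The expectation nonetheless leans toward a stronger inhibitor, with a fair chance that compound 3 also stays at the limit. The estimate for compound 3 is 5000 nM, between 500 nM and 20000 nM, which would be expected to amount to a step of an at least 4.0-fold lower number from compound 2 to compound 3 (0.60 log units; beyond the scatter).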

Compound 3, half-maximal inhibitory concentration: > 20000 nM
Compound 3: a limit, no number (the forecaster's own chance of this, stated with the estimate: 40%); middle value at least 4.0-fold (0.60 log units) away from the limit.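

In this assay, compound 3 also ends at a limit rather than a number, so its steps from compound 1 and from compound 2 cannot be read: the limit of > 20000 nM in this assay, at which 3 of the 3 values shown sit.

The compounds shown leave open how far each one lies past that limit, and whether the number or placing of methoxy groups changes antiproliferative activity at all.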